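This account rests on a few compounds, and the source may have more. Where it says the series, first, only, none or still open, it means among the compounds named here.

Measured compounds in a functional assay on A498 cells (Homo sapiens) for antiproliferative activity, read by sulforhodamine B assay, with a stated time of 48 h; on this read-out higher numbers stand for lower toxicity in this test and lower numbers for higher toxicity in this test:
- compound 1 `Nc1nn(C(=O)Nc2ccc(Cc3ccccc3)cc2)c2ccccc12`: 59600 nM
- compound 2 `Nc1nn(C(=O)Nc2ccc(Cc3ccccc3)cc2)c2ccc(Cl)cc12`: reported only as a limit, > 100000 nM

The value of compound 2 is a limit of this assay and not a number; it sits at the limit of > 100000 nM in this assay, at which 1 of the 2 values shown sits. Among the compounds with values here, the one measured step, an at least 1.6-fold higher number from compound 1 to compound 2 (0.22 log units; that floor lies within the scatter), adds a chloro and stays within the scatter. Compound 3 `Nc1ccc2c(c1)c(N)nn2C(=O)Nc1ccc(Cc2ccccc2)cc1` differs from compound 2 by amino in place of chloro on an aromatic carbon. Within the data shown here, no measured step replaces chloro with amino, so that change has no direct precedent here. With only a step within scatter to go on, no change beyond the scatter is expected. Compound 3 is expected near 80000 nM, in a range from 30000 nM to 200000 nM. The expected step is an at least 1.2-fold lower number from compound 2 to compound 3 (0.09 log units; that floor lies within the scatter).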

Compound 3, concentration lethal to 50% of the cells: 56100 nM
For compound 3 the middle estimate is 1.4-fold (0.15 log units) above the measured one, and the stated range covers the measured number.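

In this assay, placing amino on this aromatic carbon gives a direct comparison with hydrogen, and the step is a 1.1-fold lower number from compound 1 to compound 3 (0.03 log units; within the scatter). Against chloro at the same place, the step is an at least 1.7-fold lower number from compound 2 to compound 3 (0.25 log units; that floor lies within the scatter). Compound 2 is reported only as a limit of the assay and not as a number, so this second step has only a floor: the limit of > 100000 nM in this assay, at which 1 of the 3 values shown sits.

Whether chloro truly differs from hydrogen or amino here remains unsettled. Also open, from the compounds shown here alone, is whether another group on this carbon, such as a carboxylic acid or a methoxy group, would move the number beyond the scatter.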